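Hydroxy in Place of Morpholin-4-yl on the Carbonyl

This account rests on a few compounds, and the source may have more. Where it says the series, first, only, none or still open, it means among the compounds named here.

Measured compounds:
compound 1, `CCOC(=O)/C=C/c1ccncc1-c1ccc2c(cnn2C)c1`: 100%
compound 2, `Cn1ncc2cc(-c3cnccc3/C=C/C(=O)N3CCOCC3)ccc21`: 95%

Both compounds were tested in an assay on a protein complex for inhibition of CDK8/Cyclin C (Homo sapiens), with a stated time of 1 h, tested at 10 uM; a higher number here means more inhibition at the concentration tested (going by the name of the read-out), a lower number less inhibition. Compound 1 gives 100% and compound 2 gives 95%. Within the data shown here, compound 2 thus stands at the lower of the two numbers, with compound 1 as its only neighbour, and the single measured step, a number 5 percentage points lower from compound 1 to compound 2 (within the scatter), lies within the scatter, so no order between the two can be read from it.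

Compound 3, `Cn1ncc2cc(-c3cnccc3/C=C/C(=O)O)ccc21`, is the next step on this core. It differs from compound 2 by hydroxy in place of morpholin-4-yl on a carbonyl carbon. Among the measured compounds shown here, the only step that bears on this change is the one just described, which also exchanged the group on the same carbonyl carbon and moved the number in this assay by an amount within the scatter. On that basis the author expects compound 3 to stay in the same high region, with at most a modest drop beyond the scatter remaining possible. Compound 3 is expected to give about 85%, with a range of 55% to 100%. This corresponds to an expected step of a number 10 percentage points lower from compound 2 to compound 3 (within the scatter).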

Compound 3, a percentage reported as inhibition, at one concentration (the size of the read-out at that concentration, not a potency): 102%
For compound 3 the middle estimate is 17 percentage points below the measured one; measured number outside the range, above it.
By their numbers in this assay, from the lowest: compounds 2, 1 and 3 (each within the scatter of the next).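

In this assay the exchange of morpholin-4-yl for hydroxy on the carbonyl carbon, a step of a number 7 percentage points higher from compound 2 to compound 3 (within the scatter), removes a six-membered ring of 6 heavy atoms and leaves 1 heavy atom, yet the two compounds cannot be told apart. The free carboxy group of compound 3 also cannot be told apart from the ethyl ester of compound 1, with a step of a number 2 percentage points higher from compound 1 to compound 3 (within the scatter), so at this position the read-out separates none of the three groups now seen on this carbonyl carbon, whether ethoxy, morpholin-4-yl or hydroxy. No supporting measurement is available to explain this result.

From the compounds shown here alone, what remains open is whether any group on this carbonyl carbon would give a step beyond the scatter, for example a simple primary amine forming a primary amide, a longer alkoxy chain, or a nitrile in place of the whole carboxy group. Each reading also comes from a single concentration, so it gives only the size of the effect at that concentration, and these compounds may still show a stronger or weaker effect at other concentrations, which a measurement at one concentration cannot show.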